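Working notes on the shared core: expected clearance of compound 4

A few compounds are considered here, and "the series" means these few. Any claim that something is new, unique, unknown or untested is made for them only; others in the source may bear on it.

Measured compounds:
compound 1 `CC(c1c(F)cc2ncccc2c1F)n1cnc2ncc(-c3cnn(CCO)c3)nc21` — 10 uL/min
compound 2 `CNC(=O)c1ccc(-c2cnc3ncn(C(C)c4cc5cccnc5cc4F)c3n2)cc1F` — 85 uL/min
compound 3 `CC(c1cc2cccnc2cc1F)n1cnc2ncc(-c3ccc(C(N)=O)c(F)c3)nc21` — 85 uL/min

In an ADME assay on microsomes from liver (Rattus norvegicus) for metabolic stability, read by LC-MS, using NADPH, with stated times of 5 min and 30 min, tested at 1 uM (a higher number here means faster removal of the compound, a lower number slower removal), compound 1 gives the lowest of the three numbers; compound 2 and compound 3 sit well above it, beyond the scatter, and close to each other. Among the compounds with values here, the only single-site step measured, no change at the digits printed from compound 2 to compound 3 (within the scatter), concerns an amide nitrogen and does not touch the position that changes on the way to compound 4 `CC(c1c(F)cc2ncccc2c1F)n1cnc2ncc(-c3cnc4ccccc4c3)nc21`: quinolin-3-yl in place of 1-(2-hydroxyethyl)-1H-pyrazol-4-yl on an aromatic carbon. Within the data shown here, no measured pair covers this exchange, so the expectation rests on the standing of compound 1 alone and on the fact that both other compounds run far higher. A rise toward those values is expected rather than a fall. The expected step is a 4.0-fold higher number from compound 1 to compound 4 (0.60 log units; beyond the scatter). Compound 4 is estimated at 40 uL/min, with a range from 15 uL/min to 110 uL/min.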

Compound 4, intrinsic clearance in a liver preparation (reported as CLH), per the amount of preparation that the assay uses: 275 uL/min
The estimate for compound 4 lay 6.9-fold (0.84 log units) below the measured number; the whole stated range lies below it.
By their numbers in this assay, from the lowest: compound 1; then compounds 2 and 3 (each within the scatter of the next); then compound 4.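

This position on the shared core, on an aromatic carbon next to the ring nitrogen, responds strongly to the group it carries. In this assay, quinolin-3-yl in place of 1-(2-hydroxyethyl)-1H-pyrazol-4-yl gives a 28-fold higher number from compound 1 to compound 4 (1.44 log units; beyond the scatter), whereas the earlier step concerned only an amide nitrogen. Nothing available accounts for the size of this step.

Still open, going by these compounds, is whether the rise follows from removing the hydroxyethyl chain, from the pyrazole-to-quinoline exchange, or from both. A 1-methyl-1H-pyrazol-4-yl or a pyridin-3-yl at this position would help separate these readings.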